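Replacing the aryl ether in an amide side chain

The compounds below may be only part of what the source reports. "The series", "measured", "known", "first", "only" and "open" are said of these compounds alone.

Measured compounds:
- compound 1, `COc1ccc(OCC(=O)N2CCN(c3ccc(C(F)(F)F)cc3[C@@H](N)CC(C)C)CC2)cc1`: 3800 nM
- compound 2, `CC(C)C[C@H](N)c1cc(C(F)(F)F)ccc1N1CCN(C(=O)C(C)Cc2ccc(Cl)cc2O)CC1`: 36 nM
- compound 3, `CC(C)C[C@H](N)c1cc(C(F)(F)F)ccc1N1CCN(C(=O)CC(C)C(=O)c2ccc(Cl)cc2)CC1`: 1100 nM

All three share one core and differ only in the group on the amide carbonyl. In an assay on HEK293 cells for displacement of a labelled ligand from Melanocortin receptor 4 (Homo sapiens) (a higher number here means a weaker inhibitor, a lower number a stronger inhibitor), compound 1 gives the highest of the three numbers; compound 3 sits nearest, a 3.5-fold lower number from compound 1 to compound 3 (0.54 log units; beyond the scatter), and compound 2 furthest, a 110-fold lower number from compound 1 to compound 2 (2.02 log units; beyond the scatter).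

Compound 4, `CC(C)C[C@H](N)c1cc(C(F)(F)F)ccc1N1CCN(C(=O)CCNC2CCCCC2)CC1`, has not been measured. It differs from compound 1 as follows: (cyclohexylamino)methyl in place of 4-methoxyphenoxy on a saturated chain carbon bound to a carbonyl carbon.

Going by the values given here, two measured steps bear on this change, both starting from compound 1 and both replacing the same 4-methoxyphenoxy group: the modest step to compound 3 and the large step to compound 2. Both lowered the number, so a lower number is expected for compound 4 in this assay too, though the size is uncertain because nothing measured contains a (cyclohexylamino)methyl group.

Compound 4 is therefore expected to give about 800 nM, with a range from 150 nM to 4000 nM. That estimate corresponds to an expected step of a 4.8-fold lower number from compound 1 to compound 4 (0.68 log units; beyond the scatter).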

Compound 4, inhibition constant: 4800 nM
Beside the measured number, compound 4's estimate is 6.0-fold (0.78 log units) below it; the measured number lies above the stated range.
By their numbers in this assay, from the lowest: compound 2; then compound 3; then compounds 1 and 4 (each within the scatter of the next).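

In this assay, putting (cyclohexylamino)methyl in place of 4-methoxyphenoxy gives a 1.3-fold higher number from compound 1 to compound 4 (0.10 log units; within the scatter), so the lower numbers seen with the earlier replacements do not extend to every group at this position. Set against those replacements, the same chain gives a 4.4-fold higher number from compound 3 to compound 4 (0.64 log units; beyond the scatter) and a 130-fold higher number from compound 2 to compound 4 (2.12 log units; beyond the scatter), which places the two side chains carrying a chlorophenyl ring at lower numbers than either the aryl ether or the cyclohexylamine chain. No supporting data bear on why these side chains differ.

The compounds shown leave open whether the nitrogen or the cyclohexyl ring sets the number for compound 4. A cyclohexylpropyl group, with carbon in place of that nitrogen, or a 2-(benzylamino)ethyl group, with an aromatic ring in place of the cyclohexyl ring, would separate the two.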